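A chlorophenyl swap on a weakly cytotoxic series

This account rests on a few compounds, and the source may have more. Where it says the series, first, only, none or still open, it means among the compounds named here.

Measured in a functional assay on DLA cells (Mus musculus) for cytotoxicity, read by LDH release, with a stated time of 48 h; on this read-out lower numbers stand for stronger inhibition and higher numbers for weaker inhibition:
- compound 1 `COc1ccc(C(=O)c2cc(C)ccc2OCC(=O)NNC(=O)c2cc3ccccc3oc2=O)cc1`: 43400 nM
- compound 2 `Cc1ccc(OCC(=O)NNC(=O)c2cc3ccccc3oc2=O)c(C(=O)c2cccc(Cl)c2)c1`: 67400 nM
- compound 3 `Cc1ccc(OCC(=O)NNC(=O)c2cc3ccccc3oc2=O)c(C(=O)c2ccccc2)c1`: 87000 nM

These three compounds share one core and differ only in the aryl group on the carbonyl carbon. Compound 1 stands within the scatter of both others, so the numbers do not set it apart from either.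

The next compound to be tested is compound 4 `Cc1ccc(OCC(=O)NNC(=O)c2cc3ccccc3oc2=O)c(C(=O)c2ccccc2Cl)c1`. It departs from compound 1 as follows: 2-chlorophenyl in place of 4-methoxyphenyl on a carbonyl carbon. In short, 2-chlorophenyl takes the place of 4-methoxyphenyl on a carbonyl carbon.

Going by the values given here, no measured compound carries the 2-chlorophenyl group, so the evidence is indirect. The closest case is compound 2, which has a 3-chlorophenyl group at that place and gives a 1.6-fold higher number from compound 1 to compound 2 (0.19 log units; within the scatter). Removing the methoxy gives a 2.0-fold higher number from compound 1 to compound 3 (0.30 log units; within the scatter), and removing the chloro gives a 1.3-fold higher number from compound 2 to compound 3 (0.11 log units; within the scatter). All three steps stay within the scatter, so no step beyond the scatter is expected in this assay, and no direction is firmly indicated.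

The step expected is a 1.5-fold higher number from compound 1 to compound 4 (0.18 log units; within the scatter).

For compound 4 the estimated value is 65000 nM, with an expected range from 30000 nM to 130000 nM.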

Compound 4, half-maximal inhibitory concentration: 54400 nM
Compound 4: middle estimate off by 1.2-fold (0.08 log units), on the high side; the measured number falls inside the stated range.
By their numbers in this assay, from the lowest: compounds 1, 4, 2 and 3 (each within the scatter of the next).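

Going by these compounds alone, compound 4 is the first compound to carry a chloro group on this aryl ring at a place other than that of compound 2, and in this assay the swap of 2-chlorophenyl for 3-chlorophenyl on the carbonyl carbon gives a 1.2-fold lower number from compound 2 to compound 4 (0.09 log units; within the scatter), so the two chlorophenyl groups are not told apart. Adding the chloro to the unsubstituted phenyl group gives a 1.6-fold lower number from compound 3 to compound 4 (0.20 log units; within the scatter), and replacing 4-methoxyphenyl with 2-chlorophenyl gives a 1.3-fold higher number from compound 1 to compound 4 (0.10 log units; within the scatter), so a fourth aryl group at this place again produces no step beyond the scatter, and every comparison among the four compounds now stays inside it. No measurement in hand bears on why these aryl groups give such closely spaced numbers.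

On these data alone, it remains open whether any group at this place can move the number beyond the scatter, for instance an amine or a carboxylic acid on the phenyl ring, or a longer alkyl chain in place of the ring. The compounds shown also leave open whether changes elsewhere on the shared core, such as to the hydrazide linker, would matter more than changes to this aryl group.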